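The compounds below may be only part of what the source reports. "The series", "measured", "known", "first", "only" and "open" are said of these compounds alone.

- compound 1 `CCCCCCCCCCCCCCNC(=O)[C@H](CO)/N=C/c1ccccc1Cl`: 10300 nM
- compound 2 `CCCCCCCCCCCCCCNC(=O)[C@H](CO)/N=C/c1ccc(C)cc1`: 102000 nM

In a functional assay on cells (Homo sapiens) for cytotoxicity, read by MTT assay, with a stated time of 24 h (a higher number here means a weaker inhibitor, a lower number a stronger inhibitor), compound 2 gives the higher of the two numbers, 102000 nM, while compound 1 gives 10300 nM. The next compound, compound 3 `CCCCCCCCCCCCCCNC(=O)[C@H](CO)NCc1ccccc1Cl`, differs from compound 2 as follows: a group of 9 heavy atoms (7 carbon, 1 nitrogen, 1 chlorine; one six-membered aromatic ring of carbon only) in place of a group of 9 heavy atoms (8 carbon, 1 nitrogen; one six-membered aromatic ring of carbon only), on a saturated chain carbon bound to a carbonyl carbon and a saturated chain carbon. Among the measured compounds shown here, only one measured step bears on this change: a 9.9-fold higher number from compound 1 to compound 2 (1.00 log units; beyond the scatter). That modest step, beyond the scatter, replaced 2-chlorophenyl with 4-methylphenyl, and the entering (2-chlorobenzyl)amino group again holds chlorine. For the measured compounds named here, a move towards a lower number is therefore expected, though the data contain no measured step for the loss of the double bond, so the expected size is somewhat smaller and uncertain. The estimated change is a 6.4-fold lower number from compound 2 to compound 3 (0.80 log units; beyond the scatter). For compound 3, the expected value is 16000 nM, within an estimated range of 4500 nM to 60000 nM.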

Compound 3, half-maximal inhibitory concentration: 43700 nM
The estimate for compound 3 lay 2.7-fold (0.44 log units) below the measured number; the measured number falls inside the stated range.
By their numbers in this assay, from the lowest: compound 1; then compound 3; then compound 2.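

Compound 1 and compound 3 both carry the 2-chlorophenyl ring, so this pair isolates the loss of the double bond at this position: in this assay, the (2-chlorobenzyl)amino group, which adds a hydrogen-bond donor, gives a 4.2-fold higher number from compound 1 to compound 3 (0.63 log units; beyond the scatter). The same group gives a 2.3-fold lower number from compound 2 to compound 3 (0.37 log units; beyond the scatter), a step beyond the scatter that changes the link and the ring substituent together, so it cannot assign the shift to either one. No measurement here explains either step.

The compounds shown leave open whether the link and the ring substituent act independently, which a (4-methylbenzyl)amino group on the same scaffold would test. They also leave open how a plain benzylamino group, without chlorine, would compare with compound 3.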